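The source may report more compounds than this note shows. Statements on the series, on what has been measured and on what is new or still open speak of the compounds shown alone.

Compound 1 `COC(=O)c1ccc(/N=N/N(C)C(=O)CCc2cccc(O)c2)cc1`: 7.8 h
Compound 2 `CC(=O)c1ccc(/N=N/N(C)C(=O)CCCCc2ccc(O)cc2)cc1`: 32.7 h

In an ADME assay on a cell-free system (plasma, Homo sapiens) for metabolic stability, read by HPLC (on this read-out higher numbers stand for a longer-lived compound and lower numbers for a shorter-lived compound), compound 2 gives 32.7 h, the higher of the two numbers, and compound 1 lies lower by more than the scatter. Compound 3 `COC(=O)c1ccc(/N=N/N(C)C(=O)CCCCc2ccc(O)cc2)cc1` has methoxy in place of methyl on a carbonyl carbon. Within the data shown here, no measured pair shows this change alone. A fall in this assay is nevertheless expected because compound 1 with its methoxy on a carbonyl carbon gives 7.8 h. The estimated change is a 2.3-fold lower number from compound 2 to compound 3 (0.37 log units; beyond the scatter). Compound 3 is estimated at 14 h, with an expected range from 6 h to 30 h.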

Compound 3, half-life: 17.5 h
For compound 3 the middle estimate is 1.3-fold (0.10 log units) below the measured one; the measured number falls inside the stated range.
By their numbers in this assay, from the lowest: compound 1; then compounds 3 and 2 (each within the scatter of the next).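

In this assay methoxy in place of methyl on a carbonyl carbon gives a 1.9-fold lower number from compound 2 to compound 3 (0.27 log units; within the scatter) and so, with the side chain of compound 2, this change alone does not separate the two compounds. The side chain makes a clearer difference: 2-(4-hydroxyphenyl)ethyl in place of 3-hydroxyphenyl gives a 2.2-fold higher number from compound 1 to compound 3 (0.35 log units; beyond the scatter) and thus accounts for the gap from compound 1. No measured property explains either step. Going by these compounds, whether the change from methyl to methoxy reads the same with the side chain of compound 1 remains open, as does the effect of placing a carboxylic acid or an amine on that carbonyl carbon.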